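Compound 1 without its 1-methyl-1H-pyrazol-4-yl group

A few compounds are considered here, and "the series" means these few. Any claim that something is new, unique, unknown or untested is made for them only; others in the source may bear on it.

For the measured compounds named here, in an ADME assay on microsomes from liver (Homo sapiens) for metabolic stability, with a stated time of 60 min, tested at 1 uM (a lower number here means that less of the compound is left, a higher number that more of the compound is left), compound 1 `COc1cc(-c2cnn3cc(OC)c(-c4cnn(C)c4)nc23)ccn1` gives 43%, the highest of the three numbers so far, ahead of compound 2 `COc1cc(-c2cnn3cc(OC)c(-c4cc(C)no4)nc23)ccn1` at 31% and compound 3 `COc1cc(-c2cnn3cc(OC)c([C@@H]4COC(C)(C)C4)nc23)ccn1` at 13%. Compound 4 `COc1cnc2c(-c3ccnc(OC)c3)cnn2c1` is unmeasured. The change is hydrogen in place of 1-methyl-1H-pyrazol-4-yl on an aromatic carbon. The measured steps bearing on it are a number 12 percentage points lower from compound 1 to compound 2 (beyond the scatter) and a number 30 percentage points lower from compound 1 to compound 3 (beyond the scatter), alongside a number 18 percentage points lower from compound 2 to compound 3 (beyond the scatter). All three exchange one group for another, and none shows what hydrogen alone does, so no step beyond the scatter is expected, though with wide uncertainty. The estimated step is a number 3 percentage points lower from compound 1 to compound 4 (within the scatter). For compound 4 the expected value is 40%, within an estimated range of 18% to 68%.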

Compound 4, percent of the compound remaining: 2%
Estimate against measurement, compound 4: 38 percentage points above; the measured number lies below the stated range.
By their numbers in this assay, from the lowest: compound 4; then compound 3; then compound 2; then compound 1.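

In this assay, hydrogen on this aromatic carbon gives the lowest number of the series: a number 41 percentage points lower from compound 1 to compound 4 (beyond the scatter), a number 29 percentage points lower from compound 2 to compound 4 (beyond the scatter), and a number 11 percentage points lower from compound 3 to compound 4 (beyond the scatter). The earlier steps shown here only ranked the groups against each other; these show that each of the three groups, aromatic or not, leaves more compound than hydrogen does. Nothing available explains this difference. From the compounds shown here alone, whether methyl or an amine on this carbon would already lift the number, or whether a five-membered ring is needed, stays open.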